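The source may report more compounds than this note shows. Statements on the series, on what has been measured and on what is new or still open speak of the compounds shown alone.

Working notes on the series, read out in a functional assay on MCF7 cells (Homo sapiens) for inhibition, read by MTT assay, with a stated time of 72 h, tested at 30 uM; a higher number here means more inhibition of growth at the concentration tested, a lower number less inhibition of growth. Within the data shown here, only two members have a measured number so far. Compound 1 (`C=CCc1ccc(OCc2cn(-c3cccc([N+](=O)[O-])c3)nn2)c(O)c1`) gives 42.3%. Compound 2 (`C=CCc1ccc(OCc2cn(-c3ccccc3Cl)nn2)c(O)c1`) gives 58.3%, the higher of the two numbers, and its gap to compound 1 lies beyond the usual scatter.

The next member is compound 3 (`C=CCc1ccc(OCc2cn(-c3ccc(Br)cc3)nn2)c(O)c1`), still unmeasured. It keeps the shared core of compound 2 and has 4-bromophenyl in place of 2-chlorophenyl on an aromatic nitrogen.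

Among the measured compounds shown here, no measured pair shows this exchange on its own, so the size of the step cannot be read from earlier data. For the measured compounds named here, the only guide is the range of the measured numbers, with compound 1 at 42.3% and compound 2 at 58.3%. A value inside or close to that range is the cautious expectation. A small downward change, not beyond the scatter, is expected, and the estimated step is a number 8.3 percentage points lower from compound 2 to compound 3 (within the scatter). For compound 3 the estimated value is 50%, with an expected range of 33% to 67%.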

Compound 3, percent growth inhibition at one concentration: 19.4%
The estimate for compound 3 lay 30.6 percentage points above the measured number; measured number below the stated range.
By their numbers in this assay, from the lowest: compound 3; then compound 1; then compound 2.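

Among these compounds, on the aromatic nitrogen of the five-membered ring, the aryl group matters far more than the earlier compounds could show: in this assay, 4-bromophenyl in place of 2-chlorophenyl gives a number 38.9 percentage points lower from compound 2 to compound 3 (beyond the scatter), a large step between two groups with the same counted heavy atoms, the same six-membered aromatic carbon ring, no hydrogen-bond donors or acceptors and no net charge. The exchange alters both the halogen and its place on the phenyl ring, so this single step cannot assign the change to either of the two. Among the compounds shown here, nothing measured so far bears on why the step is so large.

Open, on these data alone, is whether chlorine and bromine give different numbers when they occupy the same place on the phenyl ring, a comparison that would separate the identity of the halogen from its location. Also open, as far as these compounds go, is how the series responds when the phenyl ring on the aromatic nitrogen carries a group of another kind, such as an amine or a carboxylic acid, instead of a halogen or nitro group.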